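Ortho substituent removal on the styryl aryl of compound 3

The compounds below may be only part of what the source reports. "The series", "measured", "known", "first", "only" and "open" are said of these compounds alone.

Three compounds in the series carry a number in an assay on A10 cells for binding affinity to Endothelin-1 receptor (Rattus norvegicus); on this read-out higher numbers stand for weaker inhibition and lower numbers for stronger inhibition. Compound 1 `O=C(O)CCC(Oc1cccc(OCc2ccccc2)c1)c1ccccc1` gives 2000 nM in this assay, compound 2 `Cc1ccccc1/C(=C\c1cc(OCc2ccsc2)ccc1C#N)C(=O)O` gives 300 nM, and compound 3 `O=[N+]([O-])c1ccc(OCc2ccsc2)cc1/C=C(/CO)c1ccccc1Cl` gives 400 nM. Compound 3 thus holds the second highest of the three numbers; its nearest neighbour is compound 2, within the scatter, while compound 1 sits furthest off, beyond the scatter. Compound 4 `O=[N+]([O-])c1ccc(OCc2ccsc2)cc1/C=C(/CO)c1ccccc1` differs from compound 3 by hydrogen in place of chloro on an aromatic carbon, that is, 2-chlorophenyl to phenyl, ortho to a large group. Among the compounds with values here, no measured step covers this change, so a modest loss is expected, the step from compound 3 to compound 4 estimated at a 2.0-fold higher number from compound 3 to compound 4 (0.30 log units; within the scatter). Compound 4 is accordingly expected near 800 nM, within 300 nM to 2500 nM.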

Compound 4, half-maximal inhibitory concentration: 1400 nM
Compound 4: middle estimate off by 1.8-fold (0.24 log units), on the low side; measured number inside the range.
By their numbers in this assay, from the lowest: compounds 2 and 3 (each within the scatter of the next); then compounds 4 and 1 (each within the scatter of the next).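

Within the data shown here, the 2-chlorophenyl to phenyl change gives the first comparison between compounds differing in one place: in this assay, hydrogen in place of chloro gives a 3.5-fold higher number from compound 3 to compound 4 (0.54 log units; beyond the scatter) on the shared core. This step lies beyond the scatter, so the substituent on this aromatic carbon, ortho to a large group, affects the number here. No measurement at hand accounts for the loss.

From the compounds shown here alone, whether fluoro, bromo or methoxy at this place would match chloro remains open. Going by these compounds, whether the step carries over to the core of compound 2 also remains open.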